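The source may hold more compounds than are shown below. What is called first, only, known or untested is meant among the compounds shown, and "the series" means these compounds.

Measured in an assay on HEK293 cells for displacement of a labelled ligand from Melanocortin receptor 4 (Homo sapiens); a higher number here means a weaker inhibitor, a lower number a stronger inhibitor:
- compound 1 `CCC(C)C(N)c1cc(C(F)(F)F)ccc1N1CCN(C(=O)CCc2ccc(Cl)cc2Cl)CC1` gives 160 nM
- compound 2 `CC(C)C[C@H](N)c1cc(C(F)(F)F)ccc1N1CCN(C(=O)CCc2ccccc2O)CC1` gives 3300 nM

Compound 2 stands highest of the two numbers; compound 1, which differs from it in several places at once, gives a number far lower, beyond the usual scatter. Compound 3 `COc1ccc(OC)c(CCC(=O)N2CCN(c3ccc(C(F)(F)F)cc3[C@@H](N)CC(C)C)CC2)c1` is not yet measured. It differs from compound 2 only by 2,5-dimethoxyphenyl in place of 2-hydroxyphenyl on a saturated chain carbon, two bonds along the chain from a carbonyl carbon. Going by the values given here, with no measured pair isolating this change, the expectation rests on the observation that compound 1, carrying a differently substituted aryl group on the same chain, gives 160 nM. A moderate downward step a 2.8-fold lower number from compound 2 to compound 3 (0.44 log units; beyond the scatter) is expected, probably beyond the scatter. Compound 3 is estimated at 1200 nM, in the range 400 nM to 3600 nM.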

Compound 3, inhibition constant: 2500 nM
Compound 3: the middle estimate sits 2.1-fold (0.32 log units) below what was measured; the measured number falls inside the stated range.
By their numbers in this assay, from the lowest: compound 1; then compounds 3 and 2 (each within the scatter of the next).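

In this assay, going by these compounds alone, the first isolated change at this position, 2,5-dimethoxyphenyl in place of 2-hydroxyphenyl on the saturated chain carbon, gives a 1.3-fold lower number from compound 2 to compound 3 (0.12 log units; within the scatter). Exchanging the one hydrogen-bond donor for a group with none thus leaves the two values indistinguishable here. No supporting measurement bears on this result.

Compound 1 differs from compound 2 in several places, so which difference accounts for its separate value remains open. On these data alone, how unsubstituted phenyl or a carboxylic acid at this position would read also remains open.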